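Swapping Methyl for Fluoro on the Shared Core

This account rests on a few compounds, and the source may have more. Where it says the series, first, only, none or still open, it means among the compounds named here.

All three measured compounds were tested in a functional assay on MCF7 cells (Homo sapiens) for cytotoxicity, read by MTT assay, with a stated time of 24 h; on this read-out lower numbers stand for stronger inhibition and higher numbers for weaker inhibition.
Compound 1 `Cc1ccc2oc(-c3ccc(NC(=O)CN4CCN(CCN(C)C)CC4)cc3)nc2c1`: 23700 nM
Compound 2 `Cc1ccc2oc(-c3ccc(NC(=O)CN4CCN(CCN(C)C)CC4)c(C)c3)nc2c1`: 90300 nM
Compound 3 `Cc1cc(-c2nc3cc(F)ccc3o2)ccc1NC(=O)CCl`: > 100000 nM, which is a limit of the assay and not a number.

Among the two numbers available, compound 1 gives the lowest, and the step of a 3.8-fold higher number from compound 1 to compound 2 (0.58 log units; beyond the scatter) is the only measured comparison. Compound 3 sits at the limit of > 100000 nM in this assay, at which 1 of the 3 values shown sits.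

Compound 4 `CN(C)CCN1CCN(CC(=O)Nc2ccc(-c3nc4cc(F)ccc4o3)cc2)CC1` is not yet measured. It differs from compound 1 by fluoro in place of methyl on an aromatic carbon. Among the measured compounds shown here, the one measured step, from compound 1 to compound 2, concerns a different position and a different kind of change, so it offers only a loose guide: it shows that a single small substituent on an aromatic carbon can move the number modestly. Compound 3 carries the same fluoro-bearing core as compound 4 but a different side chain, so its limit cannot be turned into a step.

On this basis compound 4 is expected to stay close to compound 1, with a step of a 1.3-fold higher number from compound 1 to compound 4 (0.10 log units; within the scatter) that lies within the usual scatter. The estimate for compound 4 in this assay is 30000 nM, in the range 12000 nM to 80000 nM.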

Compound 4, half-maximal inhibitory concentration: 20800 nM
Estimate against measurement, compound 4: 1.4-fold (0.16 log units) above; the measured number falls inside the stated range.
By their numbers in this assay, from the lowest: compounds 4 and 1 (each within the scatter of the next); then compound 2. At a limit, above all of these: compound 3.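

In this assay the change from 5-methyl-1,3-benzoxazol-2-yl to 5-fluoro-1,3-benzoxazol-2-yl gives a 1.1-fold lower number from compound 1 to compound 4 (0.06 log units; within the scatter) and so produces no difference that can be told apart from the ordinary variation between repeated measurements. Among the compounds shown here, this is the first reading at this place on the shared core, since the only earlier comparison concerned a different place and a different change, methyl in place of hydrogen, and gave a 3.8-fold higher number from compound 1 to compound 2 (0.58 log units; beyond the scatter) which lay beyond the scatter. At this place, then, a methyl group and a fluoro group are interchangeable as far as this read-out can show, though the measurements shown offer no explanation for that.

Going by these compounds, only these two small groups are seen at this place, so it remains open whether a methoxy group, a trifluoromethyl group, an amine or a carboxylic acid there would shift the number, or whether plain hydrogen would. Also open, on these data alone, is whether a longer chain at the far end of the side chain would give the same result on the methyl and fluoro versions of the core.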